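From a Hydroxybutyl End to a Phenyl Ring

The source may hold more compounds than are shown below. What is called first, only, known or untested is meant among the compounds shown, and "the series" means these compounds.

In a functional assay on NIH3T3 cells (Mus musculus) (on this read-out lower numbers stand for an effect already at smaller amounts and higher numbers for an effect only at larger amounts of compound), compound 1 `CCC/C=C/C=C/c1cc(C#N)ccc1COC(c1ccc(C#N)cc1)c1cncn1C` gives 16.7 nM and compound 2 `Cn1cncc1C(OCc1ccc(C#N)cc1C#CCCCCO)c1ccc(C#N)cc1` gives 20.9 nM. Among the compounds with values here, these two numbers cannot be told apart, so compound 2 stands level with the only other compound measured so far. Putting 6-hydroxyhex-1-yn-1-yl in place of hepta-1,3-dien-1-yl on an aromatic carbon gave a 1.3-fold higher number from compound 1 to compound 2 (0.10 log units; within the scatter).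

Compound 3 `Cn1cncc1C(OCc1ccc(C#N)cc1C#Cc1ccccc1)c1ccc(C#N)cc1` alters compound 2 in one place, with phenyl in place of 4-hydroxybutyl on a triple-bonded carbon. Within the data shown here, that single measured step is the only evidence available. It concerns the same side chain, but neither of its two compounds carries a ring there, so it is a loose guide. Among the measured compounds shown here, it shows only that one exchange of chains left the number within the scatter. On that basis, no change beyond the scatter is expected in this assay, though the untested ring calls for a wide range. The expected step is a 1.0-fold lower number from compound 2 to compound 3 (0.02 log units; within the scatter). The estimated value for compound 3 is 20 nM, with an expected range of 7 nM to 60 nM.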

Compound 3, half-maximal effective concentration: 0.1 nM
Estimate against measurement, compound 3: 200-fold (2.30 log units) above; measured number below the stated range.
By their numbers in this assay, from the lowest: compound 3; then compounds 1 and 2 (each within the scatter of the next).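

Phenyl in place of 4-hydroxybutyl on a triple-bonded carbon gave a 210-fold lower number from compound 2 to compound 3 (2.32 log units; beyond the scatter), and 2-phenylethynyl in place of hepta-1,3-dien-1-yl on an aromatic carbon gave a 170-fold lower number from compound 1 to compound 3 (2.22 log units; beyond the scatter). The earlier pair showed that in this assay this position could take two quite different open chains, one with a hydroxyl group and one without, and stay within the scatter; the new compound shows that the same position can also respond very strongly, and here that happens with the one side chain that ends in an aromatic ring. Nothing measured here explains why this exchange has so large an effect.

The compounds shown leave open whether this result depends on the phenyl ring specifically or would also appear with another ring at the end of the triple bond, such as a pyridine ring or a cyclohexyl group. They also leave open how a substituent on the phenyl ring itself, such as a fluorine atom, a methoxy group or an amine, would shift the number in this assay.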